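The compounds below may be only part of what the source reports. "The series", "measured", "known", "first", "only" and "open" are said of these compounds alone.

Measured so far in an ADME assay on MT2 cells (Homo sapiens) for cytotoxicity, read by XTT assay, with a stated time of 4 days; on this read-out higher numbers stand for lower toxicity in this test and lower numbers for higher toxicity in this test:
- compound 1 `Cc1cc(/C=C2\SC(=S)N(Cc3ccc(C(F)(F)F)cc3)C2=O)c(C)n1-c1ccc(O)c(C(=O)O)c1`: 45900 nM
- compound 2 `Cc1cc(/C=C2\SC(=S)N(Cc3cccc(C(F)(F)F)c3)C2=O)c(C)n1-c1ccc(O)c(C(=O)O)c1`: 26300 nM
- compound 3 `Cc1cc(/C=C2\SC(=S)N(Cc3cccc(C(=O)O)c3)C2=O)c(C)n1-c1ccc(O)c(C(=O)O)c1`: reported only as a limit, > 100000 nM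

Compound 1 holds the highest of the two numbers; the nearest is compound 2, at a 1.7-fold lower number from compound 1 to compound 2 (0.24 log units; within the scatter). The value of compound 3 is a limit (the limit of > 100000 nM in this assay, at which 1 of the 3 values shown sits), not a number.

Compound 4 `Cc1cc(/C=C2\SC(=S)N(Cc3ccccc3C(F)(F)F)C2=O)c(C)n1-c1ccc(O)c(C(=O)O)c1` differs from compound 1 by 2-(trifluoromethyl)phenyl in place of 4-(trifluoromethyl)phenyl on a saturated chain carbon bound to an amide-type nitrogen in a ring. For the measured compounds named here, the one step that bears on this move is a 1.7-fold lower number from compound 1 to compound 2 (0.24 log units; within the scatter), a shift of the trifluoromethyl around the ring that stayed within the scatter. The steps of an at least 2.1-fold higher number from compound 1 to compound 3 (0.33 log units; beyond the scatter) and an at least 3.8-fold higher number from compound 2 to compound 3 (0.58 log units; beyond the scatter) involve carboxy entering and do not speak to a trifluoromethyl shift.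

For compound 4 the expected step is therefore a 1.1-fold lower number from compound 1 to compound 4 (0.06 log units; within the scatter), none beyond the scatter. The estimate for compound 4 is 40000 nM, with a range of 18000 nM to 90000 nM.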

Compound 4, half-maximal cytotoxic concentration: 28800 nM
Compound 4: middle estimate off by 1.4-fold (0.14 log units), on the high side; the measured number falls inside the stated range.
By their numbers in this assay, from the lowest: compounds 2, 4 and 1 (each within the scatter of the next). At a limit, above all of these: compound 3.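

In this assay, 2-(trifluoromethyl)phenyl completes the set of trifluoromethyl placements, and none separates from the others: a 1.6-fold lower number from compound 1 to compound 4 (0.20 log units; within the scatter) and a 1.1-fold higher number from compound 2 to compound 4 (0.04 log units; within the scatter). The gap to the carboxy-bearing benzyl group recurs with this third placement: an at least 3.4-fold lower number from compound 3 to compound 4 (0.54 log units; beyond the scatter). Compound 3 is held at a limit, not a number: the limit of > 100000 nM in this assay, at which 1 of the 4 values shown sits.

Going by these compounds, what an amine or a nitrile would give in place of trifluoromethyl remains open. So does the effect of a longer chain between the amide-type nitrogen and the aromatic ring.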